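The source may report more compounds than this note shows. Statements on the series, on what has been measured and on what is new or still open speak of the compounds shown alone.

Measured compounds in an in vitro functional assay on HEK285-7 cells for antagonist activity at prostaglandin D2 receptor 2 (Homo sapiens), read by BRET and beta-arrestin recruitment; a higher number here means a weaker inhibitor, a lower number a stronger inhibitor:
- compound 1, `O=C(O)Cc1sc(C(c2ccccc2)c2ccc(Cl)cc2)nc1-c1ccc(Cl)cc1`: 75 nM
- compound 2, `O=C(O)Cc1sc(C(c2ccccc2)c2ccc(F)c(F)c2)nc1-c1ccc(F)cc1`: 64 nM

Compound 2 has the lower of the two numbers, with compound 1 standing within the scatter of it, so the two are not told apart. Among the compounds with values here, no pair of measured compounds differs in only one place, so no measured step is available to gauge the next change.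

Compound 3, `O=C(O)Cc1sc(C(c2ccccc2)c2ccc(O)cc2)nc1-c1ccc(F)cc1`, is the next compound for this assay. Relative to compound 2 the change is 4-hydroxyphenyl in place of 3,4-difluorophenyl on a saturated chain carbon bound to two aromatic carbons. The two measured compounds show only that a halogenated phenyl at this position is tolerated in the same range; they give no reading for a hydroxyphenyl there. A modest weakening, somewhat beyond the scatter, is expected for the step of a 2.8-fold higher number from compound 2 to compound 3 (0.45 log units; beyond the scatter). Compound 3 is therefore estimated at 180 nM, with a range from 60 nM to 600 nM.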

Compound 3, half-maximal inhibitory concentration: 30 nM
Beside the measured number, compound 3's estimate is 6.0-fold (0.78 log units) above it; measured number below the stated range.
By their numbers in this assay, from the lowest: compound 3; then compounds 2 and 1 (each within the scatter of the next).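

The step of a 2.1-fold lower number from compound 2 to compound 3 (0.33 log units; beyond the scatter) in this assay comes with 4-hydroxyphenyl in place of 3,4-difluorophenyl on a saturated chain carbon bound to two aromatic carbons, and it lies beyond the scatter. Within the data shown here, this position therefore holds a phenyl with a hydroxyl and no halogen, a group with a hydrogen-bond donor and acceptor, without loss in this read-out, whereas the earlier compounds gave readings only for halogenated phenyls here. No measurement at hand accounts for the step.

On these data alone, it stays open whether the gain belongs to the added hydroxyl or to the loss of the two fluorines, since this single change does both. A methoxy group or an amine in place of the hydroxyl would show how much depends on the hydroxyl itself.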